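A cyano group added to a compound known by limits

The compounds below may be only part of what the source reports. "The series", "measured", "known", "first", "only" and "open" are said of these compounds alone.

Compound 1 `C#CCN(Cc1ccc2nc(C)nc(O)c2c1)c1cccc(C)c1`, compound 2 `C#CCN(Cc1ccc2nc(C)nc(O)c2c1)c1cccc(C(F)(F)F)c1` and compound 3 `C#CCN(Cc1ccc2nc(C)nc(O)c2c1)c1cccc(C#C)c1` share one core and differ only in a single group on an aromatic carbon: methyl, trifluoromethyl or ethynyl. All three have been tested in a functional assay on L1210 cells (Mus musculus) for inhibition; a higher number here means a weaker inhibitor, a lower number a stronger inhibitor. In this assay compound 2 reads > 2200 nM, which is a limit and not a number. Compound 1 reads > 5000 nM, also a limit. Compound 3 reads > 2400 nM, again a limit. Compound 2 therefore has no exact value, and the three cannot be ranked.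

Compound 4 `C#CCN(Cc1ccc2nc(C)nc(O)c2c1)c1ccc(C#N)c(C(F)(F)F)c1` differs from compound 2 by one change, cyano in place of hydrogen on an aromatic carbon, ortho to a trifluoromethyl group and para to a large group (cyano in place of hydrogen on an aromatic carbon). Three steps among the measured compounds could guide a forecast: a step that the two limits leave unreadable from compound 1 to compound 2, a step that the two limits leave unreadable from compound 1 to compound 3 and a step that the two limits leave unreadable from compound 2 to compound 3. None of them has a readable size, and none adds a cyano group, so they point in no direction. The expected outcome is another weak inhibitor, quite possibly reported only as a limit. The estimated change, a step that the limit leaves unreadable from compound 2 to compound 4, is therefore a rough expectation. For compound 4 the estimated value is 4000 nM, with an expected range of 1000 nM to 16000 nM.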

Compound 4, half-maximal inhibitory concentration: > 2800 nM
Compound 4: no number, only a limit; the forecaster's own chance of this, stated with the estimate: 65%; the middle value lies beyond the limit too.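

In this assay compound 4 gives > 2800 nM, which is a limit and not a number. Compound 2 also has only a limit, so the step between compound 2 and compound 4 cannot be read, and the added cyano gets no size. The compounds shown leave open how strongly each one inhibits: none has an exact value.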